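This account rests on a few compounds, and the source may have more. Where it says the series, first, only, none or still open, it means among the compounds named here.

Series notes. Of the compounds shown here, two have so far been measured in a functional assay on T-24 cells (Homo sapiens) for cytotoxicity, read by CCK-8 assay, with a stated time of 24 h; on this read-out higher numbers stand for weaker inhibition and lower numbers for stronger inhibition. Compound 1 `C=C1CCC(c2csc(/C=C(\C)C(N)=O)c2)CC1` reaches only the limit of that read-out: in this assay compound 1 gives > 50000 nM, which is a limit rather than a number. Compound 2 `C/C(=C\c1cc(-c2ccc(F)cc2)cs1)C(N)=O` behaves the same way: in this assay compound 2 gives > 50000 nM, again a limit and not a number. Going by the values given here, compound 2 therefore stands at the limit of > 50000 nM in this assay, at which 2 of the 2 values shown sit, and no step between measured compounds can be drawn from the pair, as both values are limits.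

The next compound, compound 3 `C=Cc1ccc(-c2csc(/C=C(\C)C(N)=O)c2)cc1`, differs from compound 2 by vinyl in place of fluoro on an aromatic carbon. Among the compounds with values here, no measured step speaks to a change of that kind. Nothing in the two limits points to a gain in potency, so no step beyond the scatter is expected in this assay. The expected step is a number no higher from compound 2 to compound 3 (the limit leaves the size open), essentially none. Compound 3 is accordingly estimated to give about 50000 nM in this assay, within 20000 nM to 100000 nM, and most probably again only a limit.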

Compound 3, half-maximal inhibitory concentration: > 50000 nM
Compound 3 ended at the assay's limit; the forecaster's own chance of this, stated with the estimate: 85%; the middle value lies on the limit itself.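

In this assay compound 3 gives > 50000 nM, which is a limit and not a number. No step can be read from compound 2 to compound 3, as both values are limits: the limit of > 50000 nM in this assay, at which 3 of the 3 values shown sit. The compounds shown leave open whether any change on the shared core would give a measurable value in this assay.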